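This account rests on a few compounds, and the source may have more. Where it says the series, first, only, none or still open, it means among the compounds named here.

In an ADME assay on Raji cells (Homo sapiens) for cytotoxicity, read by CellTiter-Glo, with a stated time of 72 h (on this read-out lower numbers stand for an effect already at smaller amounts and higher numbers for an effect only at larger amounts of compound), three compounds have been measured so far. Compound 1 `CC1=C2CC(C)(C)/C=C/[C@H](OC(=S)Sc3ccccc3)/C(C)=C\C3=C[C@H](C)C[C@]3(O2)C1=O` gives 26000 nM in this read-out. Compound 2 `C/C1=C/C2=C[C@H](C)C[C@@]23O[C@]2(CC(C)(C)[C@@H](O)[C@@H]2C1=O)[C@@H](C)C3=O` gives 26000 nM on the same read-out. Compound 3 `CO[C@H]1[C@@H]2C(=O)/C(C)=C\C3=C[C@H](C)C[C@@]34O[C@]2(CC1(C)C)[C@@H](C)C4=O` gives 26000 nM and so stands level with the other two.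

Compound 4 `C/C1=C/C2=C[C@H](C)C[C@@]23O[C@]2(CC(C)(C)[C@@H](OC(C)C)[C@@H]2C1=O)[C@@H](C)C3=O` has not yet been measured. It differs from compound 3 by methoxy to isopropoxy, that is, isopropyl in place of methyl on an oxygen on a saturated carbon, counted as isopropyl in place of methyl on an oxygen on a saturated carbon for this change.

Among the compounds with values here, one measured step bears on it, methyl in place of hydrogen on an oxygen on a saturated carbon, which gave no change at the digits printed from compound 2 to compound 3 (within the scatter) in that comparison. Within the data shown here, this is a single step, and no isopropyl group has yet been tested. Even so, no step beyond the scatter is expected in this assay in either direction. The expected step is no change at the digits printed from compound 3 to compound 4 (within the scatter) on this reasoning. Compound 4 is estimated at 26000 nM with an expected range from 13000 nM to 50000 nM for its measurement.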

Compound 4, half-maximal effective concentration: 26000 nM
The estimate for compound 4 equals the measured number at the digits printed; low and high end bracket the measured number.
By their numbers in this assay, from the lowest: compounds 1, 2, 3 and 4 (each within the scatter of the next).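

In this assay the change on the oxygen on a saturated carbon now goes beyond a methyl group: isopropyl in place of methyl, which takes the group from 1 heavy atom to 3 heavy atoms, gives no change at the digits printed from compound 3 to compound 4 (within the scatter). The larger change, isopropyl in place of hydrogen, gives no change at the digits printed from compound 2 to compound 4 (within the scatter), so hydrogen, methyl and isopropyl on this oxygen now stand level in this read-out. No measured evidence here accounts for this flat result.

Only these three groups are shown on this oxygen, and whether any group placed there can move the read-out stays open. A longer chain ending in an amine or a carboxylic acid would be a different kind of test of this position.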